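A few compounds are considered here, and "the series" means these few. Any claim that something is new, unique, unknown or untested is made for them only; others in the source may bear on it.

Compound 2 `CCN(Cc1ccccc1)C(=O)C1CCN(S(=O)(=O)c2ccc(OC)cc2)CC1` gives 84% in a functional assay on CHO cells for positive allosteric modulation of muscarinic acetylcholine receptor M5 (Homo sapiens), read by calcium flux (on this read-out higher numbers stand for larger maximal responses and lower numbers for smaller maximal responses), and among the two numbers in hand it stands highest. For the measured compounds named here, its nearest neighbour is compound 1 `CCN(Cc1ccccc1)C(=O)C1CCN(S(=O)(=O)c2ccccc2)CC1`, which gives 69%, so the only single change measured, methoxy in place of hydrogen on an aromatic carbon, yields a number 15 percentage points higher from compound 1 to compound 2 (beyond the scatter). Compound 3 `CCN(Cc1ccccc1)C(=O)C1CCN(S(=O)(=O)c2ccccn2)CC1` carries a pyridine in place of the benzene ring on the sulfonyl sulfur, but its result is "not determined" (no result reported), so it says nothing about the size of such a ring swap.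

Compound 4 `CCN(Cc1ccccc1)C(=O)C1CCN(S(=O)(=O)c2ccc3cn[nH]c3c2)CC1` differs from compound 2 at the same sulfonyl sulfur: 1H-indazol-6-yl in place of 4-methoxyphenyl on a sulfonyl sulfur. The incoming group keeps one hydrogen-bond acceptor and adds one hydrogen-bond donor while the methoxy is lost. Going by the values given here, the one measured step bears on it only loosely, since it tells that a change at this position can move the maximal response by a modest amount, but not what a full ring exchange does. With so little to go on, no step beyond the scatter is expected in either direction. Compound 4 is therefore estimated to give 76%, within a range of 56% to 96%, which corresponds to an expected step of a number 8 percentage points lower from compound 2 to compound 4 (within the scatter).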

Compound 4, largest response reached (reported as percent of maximum), in percent of the reference or control that the assay uses: 86%
Compound 4: middle estimate off by 10 percentage points, on the low side; measured number inside the range.
By their numbers in this assay, from the lowest: compound 1; then compounds 2 and 4 (each within the scatter of the next).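

The sulfonyl sulfur accepts a complete exchange of its aromatic group, not only a small addition to it: in this assay, 1H-indazol-6-yl in place of 4-methoxyphenyl gives a number 2 percentage points higher from compound 2 to compound 4 (within the scatter), so the two groups cannot be told apart here, even though the incoming one has a hydrogen-bond donor and the outgoing one has none. Measured against the plain phenyl group, the same indazole gives a number 17 percentage points higher from compound 1 to compound 4 (beyond the scatter), which joins the earlier a number 15 percentage points higher from compound 1 to compound 2 (beyond the scatter) and shows that two quite different groups on this sulfur both exceed phenyl. No measurement in hand explains why these two groups end up so close.

On these data alone, whether the hydrogen-bond donor plays any part stays open, and a methyl group in place of the hydrogen on the indazole nitrogen would test this directly, as would an amine in place of the methoxy in compound 2. It is also unknown how far the response depends on the amide side of the molecule, where a propyl chain in place of the ethyl would be a first probe.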